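Amide aryl trimming in the pyrazole-pyridine growth inhibitor series

A few compounds are considered here, and "the series" means these few. Any claim that something is new, unique, unknown or untested is made for them only; others in the source may bear on it.

Measured so far:
- compound 1 `O=C(Nc1cccc(-n2cc(-c3ccncc3)c(-c3ccc(Cl)c(O)c3)n2)c1)Nc1ccc(Cl)c(Cl)c1`: 1460 nM
- compound 2 `COc1cc(-c2nn(-c3cccc(NC(=O)c4ccc(Cl)c(C(F)(F)F)c4)c3)cc2-c2ccncc2)ccc1Cl`: 3080 nM
- compound 3 `COc1cc(-c2nn(-c3cccc(NC(=O)Nc4ccc(Cl)c(C(F)(F)F)c4)c3)cc2-c2ccncc2)ccc1Cl`: 1200 nM

In a functional assay on SK-MEL-28 cells (Homo sapiens) for inhibition, read by sulforhodamine B assay, with a stated time of 48 h (a higher number here means a weaker inhibitor of growth, a lower number a stronger inhibitor of growth), compound 2 gives the highest of the three numbers; compound 1 sits nearest, and compound 3 furthest. Within the data shown here, the only step between two compounds that differ in one place is the urea-for-amide exchange, a 2.6-fold lower number from compound 2 to compound 3 (0.41 log units; beyond the scatter), which says nothing about the aryl attached to the carbonyl.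

Compound 4 `COc1cc(-c2nn(-c3cccc(NC(=O)c4ccccc4)c3)cc2-c2ccncc2)ccc1Cl` is the next member. Its change from compound 2 is phenyl in place of 4-chloro-3-(trifluoromethyl)phenyl on a carbonyl carbon. Among the measured compounds shown here, no measured pair in this set alters the substituents on that ring; compounds 1, 2 and 3 all carry a substituted ring at this position, so the set gives no direct guide to stripping it bare. Loss of two groups from the aryl is a larger structural change than the one covered by a 2.6-fold lower number from compound 2 to compound 3 (0.41 log units; beyond the scatter), but its direction is unknown here. The working assumption is a step near the scatter or a modest rise in the number: the expected step is a 1.6-fold higher number from compound 2 to compound 4 (0.21 log units; within the scatter). For compound 4 the estimate in this assay is 5000 nM, with a range from 1500 nM to 16000 nM.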

Compound 4, concentration for 50% growth inhibition: 3860 nM
The estimate for compound 4 lay 1.3-fold (0.11 log units) above the measured number; low and high end bracket the measured number.
By their numbers in this assay, from the lowest: compounds 3 and 1 (each within the scatter of the next); then compounds 2 and 4 (each within the scatter of the next).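

In this assay the exchange of 4-chloro-3-(trifluoromethyl)phenyl for bare phenyl on the amide carbonyl gives a 1.3-fold higher number from compound 2 to compound 4 (0.10 log units; within the scatter) and so does not separate the two aryl groups, even though the change takes away both the chlorine and the trifluoromethyl. The exchange of (4-chloro-3-(trifluoromethyl)phenyl)amino for phenyl on the carbonyl carbon gives a 3.2-fold higher number from compound 3 to compound 4 (0.51 log units; beyond the scatter) and, read with a 2.6-fold lower number from compound 2 to compound 3 (0.41 log units; beyond the scatter) as the other step, sets the urea compound 3 apart from both amides, compound 2 and compound 4. No supporting measurement bears on either result.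

Step 3>4 changes the nitrogen and the ring substituents at once, so a plain phenylamino on the carbonyl carbon would be needed to show whether the urea nitrogen alone carries this gap. Also open, going by these compounds, is whether a phenyl with a lone chlorine or a lone trifluoromethyl, or a saturated ring such as cyclohexyl on the carbonyl carbon, would stay within the scatter of compound 4.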